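A few compounds are considered here, and "the series" means these few. Any claim that something is new, unique, unknown or untested is made for them only; others in the source may bear on it.

In a functional assay on HeLa cells (Homo sapiens) for antiproliferative activity, read by MTT assay, with a stated time of 72 h (a lower number here means a stronger inhibitor, a higher number a weaker inhibitor), compound 1 `O=C1COc2ccc(-c3cccc(NS(=O)(=O)c4ccc(F)cc4)c3)cc2N1` gives > 40000 nM, which is a limit of the assay and not a number. Compound 3 `Cc1ccc(N2C(=O)COc3ccc(-c4cnc5ccccc5c4)cc32)cc1` gives > 40000 nM, again a limit. Among the compounds with values here, compound 2 `CC(C)N1C(=O)COc2ccc(-c3cnc(Cl)c(NS(=O)(=O)c4ccc(F)cc4)c3)cc21` gives 5380 nM, the only actual number among the three measured compounds, which leaves it as the single reference point for the series.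

Compound 4 `O=C1COc2ccc(-c3cnc(Cl)c(NS(=O)(=O)c4ccc(F)cc4)c3)cc2N1c1ccccc1` keeps the rest of compound 2 and carries phenyl in place of isopropyl on an amide-type nitrogen in a ring. Within the data shown here, no measured pair isolates this change. Compound 3 also bears an aromatic ring on such a nitrogen, but it differs from compound 4 elsewhere. Compound 3 gives > 40000 nM, a limit that offers only a weak hint of lost activity. A modest loss in this assay is therefore expected, with real uncertainty about its size, and the estimated change is a 1.5-fold higher number from compound 2 to compound 4 (0.17 log units; within the scatter). For compound 4 the estimated value is 8000 nM, with an expected range from 2000 nM to 30000 nM.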

Compound 4, half-maximal inhibitory concentration: 10300 nM
Estimate against measurement, compound 4: 1.3-fold (0.11 log units) below; measured number inside the range.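

In this assay, phenyl in place of isopropyl on an amide-type nitrogen in a ring gives a 1.9-fold higher number from compound 2 to compound 4 (0.28 log units; within the scatter), so the two compounds cannot be told apart. This is the first pair shown that isolates this position, and across this change, from a group with no ring to a six-membered aromatic ring of carbon only, the read-out stays within the scatter. With phenyl on this nitrogen, compound 4 still gives a number and does not join the compounds held at the limit: the limit of > 40000 nM in this assay, at which 2 of the 4 values shown sit.

As far as these compounds go, how a longer chain, a benzyl group or a chain ending in an amine or a carboxylic acid would read on this nitrogen stays open. From the compounds shown here alone, what the chlorine and the sulfonamide of the shared core contribute also stays open.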